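Benzothiazolyl semicarbazones: indole nitrogen substituent, chloro removed

The source may hold more compounds than are shown below. What is called first, only, known or untested is meant among the compounds shown, and "the series" means these compounds.

Values in a functional assay on MDA-MB-231 cells (Homo sapiens) for cytotoxicity, read by MTT assay, with a stated time of 72 h (on this read-out lower numbers stand for stronger inhibition and higher numbers for weaker inhibition), for the three measured members of the series:

compound 1 `Cc1ccc(Cn2cc(/C=N/NC(=O)Nc3nc4ccc(CN(C)C)cc4s3)c3ccccc32)cc1`: 1220 nM
compound 2 `CN(C)Cc1ccc2nc(NC(=O)N/N=C/c3cn(Cc4ccccc4)c4ccccc34)sc2c1`: 1340 nM
compound 3 `CN(C)Cc1ccc2nc(NC(=O)N/N=C/c3cn(Cc4ccc(Cl)cc4Cl)c4ccccc34)sc2c1`: 1410 nM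

Compound 3 gives the highest of the three numbers, yet its separation from compound 2 is a 1.1-fold higher number from compound 2 to compound 3 (0.02 log units; within the scatter) and from compound 1 it is a 1.2-fold higher number from compound 1 to compound 3 (0.06 log units; within the scatter), so on these numbers the three compounds cannot be told apart.

Compound 4 `CN(C)Cc1ccc2nc(NC(=O)N/N=C/c3cn(Cc4ccc(Cl)cc4)c4ccccc34)sc2c1` differs from compound 3 by hydrogen in place of chloro on an aromatic carbon; cut one bond further out, the change reads 2,4-dichlorophenyl to 4-chlorophenyl. Within the data shown here, no measured pair shows this exact change. The pairs that bear on it all alter the same benzyl ring: a 1.1-fold higher number from compound 1 to compound 2 (0.04 log units; within the scatter), a 1.2-fold higher number from compound 1 to compound 3 (0.06 log units; within the scatter) and a 1.1-fold higher number from compound 2 to compound 3 (0.02 log units; within the scatter). Every variation of this ring so far, from unsubstituted to 4-methylphenyl to 2,4-dichlorophenyl, has left the number where it was. The expectation for compound 4 is therefore a step of a 1.0-fold lower number from compound 3 to compound 4 (0.02 log units; within the scatter), that is, none beyond the scatter in either direction. Compound 4 is estimated at 1350 nM, within 700 nM to 2700 nM.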

Compound 4, half-maximal inhibitory concentration: 880 nM
Compound 4: middle estimate off by 1.5-fold (0.19 log units), on the high side; the measured number falls inside the stated range.
By their numbers in this assay, from the lowest: compounds 4, 1, 2 and 3 (each within the scatter of the next).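

In this assay, taking away the chloro ortho to a large group on the benzyl ring gives a 1.6-fold lower number from compound 3 to compound 4 (0.20 log units; within the scatter), so hydrogen and chloro at this place cannot be told apart. The 4-chlorophenyl group also stays within the scatter of the other two rings, with a 1.5-fold lower number from compound 2 to compound 4 (0.18 log units; within the scatter) against phenyl and a 1.4-fold lower number from compound 1 to compound 4 (0.14 log units; within the scatter) against 4-methylphenyl. No measurement bears on what lies behind these steps.

On these data alone, it remains open whether any change to this ring moves the number beyond the scatter, for instance an amine or a carboxylic acid in place of the 4-chloro, or a longer chain between the ring and the indole nitrogen. All four compounds share the same core, so its contribution to the number cannot be read from them.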